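The compounds below may be only part of what the source reports. "The series", "measured", "known", "first", "only" and "open" are said of these compounds alone.

Compound 1 `Cc1ccc(/C=C/C(=O)NCC(=O)N(C)c2ccc(Cl)c(COc3cccc4sc(C)nc34)c2Cl)cc1` and compound 2 `Cc1nc2c(OCc3c(Cl)ccc(N(C)C(=O)CNC(=O)/C=C/c4ccc(C(F)(F)F)cc4)c3Cl)cccc2s1` share one core and differ only in the group on the outer aromatic ring. In a functional assay for inhibition, with Oryctolagus cuniculus as the target (on this read-out higher numbers stand for an effect only at larger amounts of compound and lower numbers for an effect already at smaller amounts), compound 1 gives 66 nM, and in this assay compound 2 gives 76 nM. The step between them, a 1.2-fold higher number from compound 1 to compound 2 (0.06 log units; within the scatter), shows that the two numbers sit within the scatter of each other, so compound 2 stands level with compound 1 and nothing more can be said about its rank on these two numbers.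

Compound 3 `COc1cccc(/C=C/C(=O)NCC(=O)N(C)c2ccc(Cl)c(COc3cccc4sc(C)nc34)c2Cl)c1` is not yet measured. It differs from compound 2 in one place: 3-methoxyphenyl in place of 4-(trifluoromethyl)phenyl on a double-bonded chain carbon bound to a double-bonded chain carbon. Within the data shown here, the only measured step that bears on this change is the one from compound 1 to compound 2, which also exchanged the group on this aromatic ring and stayed within the scatter. Nothing in the data separates the ring positions or the methoxy group from the others. Compound 3 is therefore expected to show at most a small step, a 1.3-fold higher number from compound 2 to compound 3 (0.12 log units; within the scatter), in this assay, with no direction that can be called beyond the scatter. The estimate for compound 3 is 100 nM, with a range from 40 nM to 250 nM.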

Compound 3, half-maximal effective concentration: 180 nM
Compound 3: the middle estimate sits 1.8-fold (0.26 log units) below what was measured, within the range that was stated.
By their numbers in this assay, from the lowest: compounds 1 and 2 (each within the scatter of the next); then compound 3.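

In this assay the aromatic ring on the double-bonded chain carbon now proves able to move the number: the change gives a 2.4-fold higher number from compound 2 to compound 3 (0.37 log units; beyond the scatter), and the same exchange measured against the methyl compound gives a 2.7-fold higher number from compound 1 to compound 3 (0.44 log units; beyond the scatter), both modest but beyond the scatter. The earlier step between methyl and trifluoromethyl had stayed within the scatter, so this position had seemed to tolerate change, whereas 3-methoxyphenyl, which brings one hydrogen-bond acceptor where the other two rings bring none, goes with a higher number than either 4-methylphenyl or 4-(trifluoromethyl)phenyl. Nothing among the available data gives a reason for this shift.

The change swaps both the group and its place on the ring at once, and the three compounds shown do not separate whether the higher number goes with the methoxy group or with where it sits. Also open, from the compounds shown here alone, is how the number would respond to an amine or a carboxylic acid on this ring, or to a longer chain in place of the ethenyl link.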